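The compounds below may be only part of what the source reports. "The series", "measured", "known", "first", "only" and "open" are said of these compounds alone.

Working notes on the series, values in an ADME assay on MDBK cells (Bos taurus) for cytotoxicity; on this read-out lower numbers stand for higher toxicity in this test and higher numbers for lower toxicity in this test:

- compound 1 `Cc1ccc(Cn2ccc3nc(-c4ccccc4)nc-3c2)cc1`: > 100000 nM (a limit of the assay)
- compound 2 `CC(C)(C)c1ccc(Cn2ccc3nc(-c4ccccc4)nc-3c2)cc1`: 22000 nM
- compound 3 `c1ccc(-c2ccc(Cn3ccc4nc(-c5ccccc5)nc-4c3)cc2)cc1`: 18000 nM

Compound 3 sits level with compound 2, as a 1.2-fold lower number from compound 2 to compound 3 (0.09 log units; within the scatter) shows. Compound 4 `O=C(O)c1ccc(Cn2ccc3nc(-c4ccccc4)nc-3c2)cc1` has carboxy in place of phenyl on an aromatic carbon, para to a large group: carboxy in place of phenyl on an aromatic carbon.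

The relevant steps both start from the methyl of compound 1. These are an at least 4.5-fold lower number from compound 1 to compound 2 (0.65 log units; beyond the scatter) and an at least 5.5-fold lower number from compound 1 to compound 3 (0.74 log units; beyond the scatter), each beyond the scatter, while tert-butyl and phenyl do not separate from each other. By the count of heavy atoms, carboxy is the smaller group leaving less on that carbon, so compound 4 is expected to fall closer to compound 1 than to compound 3. Among the compounds with values here, this rests on only three compounds, and none of them carries a group like carboxy. The expected change is a move to a higher number, about as large as the steps from compound 1 but opposite in direction. The estimated change is a 5.0-fold higher number from compound 3 to compound 4 (0.70 log units; beyond the scatter). A reading that gives only a limit is quite possible. For compound 4 the estimated value is 90000 nM, with an expected range of 30000 nM to 200000 nM.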

Compound 4, half-maximal cytotoxic concentration: > 100000 nM
Compound 4: a limit, no number; the forecaster's own chance of this, stated with the estimate: 60%; middle value at least 1.1-fold (0.04 log units) from the limit.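

In this assay, carboxy on this aromatic carbon, para to a large group, gives an at least 5.5-fold higher number from compound 3 to compound 4 (0.74 log units; beyond the scatter) and an at least 4.5-fold higher number from compound 2 to compound 4 (0.65 log units; beyond the scatter). The lower numbers seen with phenyl and tert-butyl therefore do not extend to every replacement for methyl at this position. Compound 4 gives a limit and not a number, and the step between compound 1 and compound 4 cannot be read, so carboxy and methyl cannot be ordered in this assay: the limit of > 100000 nM in this assay, at which 2 of the 4 values shown sit.

From the compounds shown here alone, how far the true values of compound 1 and compound 4 lie from this limit stays open. Also open, going by these compounds, is whether an amine, a methyl ester or a longer chain on this carbon would read with phenyl and tert-butyl or at the limit, which bears on whether group size or group identity tracks the read-out.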